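The source may hold more compounds than are shown below. What is called first, only, known or untested is meant among the compounds shown, and "the series" means these compounds.

Measured compounds:
compound 1 `Nc1nc(N/N=C/c2cccc(OCc3ccccc3)c2)nc2c1ncn2[C@@H]1O[C@H](CO)[C@@H](O)[C@H]1O` — 13 nM in an assay on CHO-K1 cells for displacement of a labelled ligand from adenosine receptor A1 (Homo sapiens), read by scintillation counting, with a stated time of 60 min; on this read-out higher numbers stand for weaker inhibition and lower numbers for stronger inhibition
compound 2 `Nc1nc(N/N=C/c2ccc(-c3ccccn3)cc2)nc2c1ncn2[C@@H]1O[C@H](CO)[C@@H](O)[C@H]1O` — 7540 nM in this assay
compound 3 `Nc1nc(N/N=C/c2ccc(OCc3ccccc3)c(OCc3ccccc3)c2)nc2c1ncn2[C@@H]1O[C@H](CO)[C@@H](O)[C@H]1O` — in this assay compound 3 reaches only a limit, > 10000 nM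

Compound 2 stands highest of the two numbers given; its nearest neighbour is compound 1, whose number is far lower. Compound 3 sits at the limit of the assay (the limit of > 10000 nM in this assay, at which 1 of the 3 values shown sits), so it gives no number. Among the compounds with values here, the one measured step between compounds that differ in a single place is an at least 760-fold higher number from compound 1 to compound 3 (2.88 log units; beyond the scatter), a large worsening.

Compound 4 `Nc1nc(N/N=C/c2ccc(N3CCCC3)cc2)nc2c1ncn2[C@@H]1O[C@H](CO)[C@@H](O)[C@H]1O` differs from compound 2 by pyrrolidin-1-yl in place of pyridin-2-yl on an aromatic carbon. Within the data shown here, no measured step concerns a change at this position, so the single large step seen elsewhere on the shared core gives no direct guide. Because compound 2 already gives 7540 nM, a weak starting point, and the new group is of similar size to the one it replaces, a step of modest size is expected, with direction uncertain: a 2.5-fold lower number from compound 2 to compound 4 (0.40 log units; beyond the scatter). Compound 4 is therefore estimated at 3000 nM, with a range from 500 nM to 15000 nM.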

Compound 4, inhibition constant: 5.1 nM
Compound 4: middle estimate off by 590-fold (2.77 log units), on the high side; the whole stated range lies above it.
By their numbers in this assay, from the lowest: compound 4; then compound 1; then compound 2. At a limit, above all of these: compound 3.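

The group on this aromatic carbon, para to a large group, has a very strong influence in this assay: pyrrolidin-1-yl in place of pyridin-2-yl gives a 1500-fold lower number from compound 2 to compound 4 (3.17 log units; beyond the scatter). The two groups are alike in several counts, each being a single ring with one nitrogen, no hydrogen-bond donors, one hydrogen-bond acceptor and no net charge, yet they are far from interchangeable here, and what separates them is a five-membered non-aromatic ring against a six-membered aromatic one. Nothing measured here explains why this change has so large an effect.

From the compounds shown here alone, it remains open whether ring size, the loss of the aromatic ring or attachment through nitrogen matters most. A piperidin-1-yl group or a phenyl ring here would help separate these, and an open-chain dimethylamino group would test whether a ring is needed at all.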